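The compounds below may be only part of what the source reports. "The series", "measured", "known", "first", "only" and "open" are said of these compounds alone.

Compound 1 `CC(C)C1=C(C(=O)N2[C@H](C)CC[C@H]2C(=O)N2CCN(C)CC2)SC2=N[C@@](C)(c3ccc(Cl)cc3)[C@@H](c3ccc(Cl)cc3)N21`: 45 ug/mL
Compound 2 `CC[C@@H]1CC[C@@H](C(=O)N2CCOCC2)N1C(=O)C1=C(C(C)C)N2C(=N[C@@](C)(c3ccc(Cl)cc3)[C@H]2c2ccc(Cl)cc2)S1`: 9 ug/mL

Both values come from a physicochemical assay for solubility, read by HPLC, in phosphate buffer, at pH 6.8; on this read-out higher numbers stand for higher solubility and lower numbers for lower solubility. On these two numbers compound 1 stands highest at 45 ug/mL, and compound 2 lies at 9 ug/mL, a gap beyond the usual scatter. The two compounds differ in more than one place, so this gap is not a measured step for any single change.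

Compound 3 `CC(C)C1=C(C(=O)N2[C@H](C)CC[C@H]2C(=O)N2CCN(C)C(C)(C)C2)SC2=N[C@@](C)(c3ccc(Cl)cc3)[C@@H](c3ccc(Cl)cc3)N21` keeps the core of compound 1 and changes one group, on a carbonyl carbon: a group of 9 heavy atoms (7 carbon, 2 nitrogen; one six-membered non-aromatic ring with 2 hetero atoms) in place of a group of 7 heavy atoms (5 carbon, 2 nitrogen; one six-membered non-aromatic ring with 2 hetero atoms), on a carbonyl carbon. For the measured compounds named here, no measured single-change step is available as a guide, so the expectation rests on compound 1 at 45 ug/mL alone. In this assay a modest fall is expected, possibly none beyond the scatter, and the estimated step is a 1.5-fold lower number from compound 1 to compound 3 (0.18 log units; within the scatter). The estimated value for compound 3 is 30 ug/mL, with an expected range of 10 ug/mL to 90 ug/mL.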

Compound 3, solubility: 30 ug/mL
Beside the measured number, compound 3's estimate shows no gap at the digits printed, within the range that was stated.
By their numbers in this assay, from the lowest: compound 2; then compounds 3 and 1 (each within the scatter of the next).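

For the compounds shown here, on a carbonyl carbon whose other neighbours are a saturated ring carbon, replacing 4-methylpiperazin-1-yl with the group of 9 heavy atoms gives a 1.5-fold lower number from compound 1 to compound 3 (0.18 log units; within the scatter) in this assay, the first single-change step. This position therefore accepts the two added heavy atoms, both carbon, with no shift beyond the scatter, while the six-membered non-aromatic ring, its 2 hetero atoms and the hydrogen-bond donor and acceptor counts stay the same. No measured evidence bears on the reason for this result.

Still open, going by these compounds, is whether a group of a different kind on that carbonyl carbon, such as a carboxylic acid or a primary amine, would give a step beyond the scatter. Also open, on these data alone, is whether this step would hold on a core other than that of compound 1.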